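Nitro for methyl on the shared core: working notes

The source may report more compounds than this note shows. Statements on the series, on what has been measured and on what is new or still open speak of the compounds shown alone.

Three compounds of the series have been run in a toxicity assay on the whole organism with Rattus norvegicus as the target, at a dose of 100 mg/kg by the oral route; on this read-out higher numbers stand for a stronger effect at the one dose given and lower numbers for a weaker effect. Compound 1 `Cc1ccccc1OCC1=NCCO1` gives 40%. Compound 2 `Cc1cccc(OCC2=NCCO2)c1` is built from the same atoms joined differently, and the difference between the two cores is not broken down here; compound 2 gives 50%. Compound 3 `O=[N+]([O-])c1ccccc1OCC1=NCCO1` gives 30%.

One counted change occurs between measured compounds, (nitro in place of methyl on an aromatic carbon), and it gave a number 10 percentage points lower from compound 1 to compound 3 (within the scatter). The gap between compound 2 and compound 1 lies within the scatter, the gap between compound 2 and compound 3 beyond it.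

Compound 4 `O=[N+]([O-])c1cccc(OCC2=NCCO2)c1` has not been measured. From compound 2 it differs by nitro in place of methyl on an aromatic carbon. This is the same kind of change as that from compound 1 to compound 3, not the same: in compound 3 the nitro stands ortho to a group of 7 heavy atoms, in compound 4 meta to a group of 7 heavy atoms.

For compound 4 the expected step is a number 10 percentage points lower from compound 2 to compound 4 (within the scatter), resting on the single earlier occurrence that gave a number 10 percentage points lower from compound 1 to compound 3 (within the scatter). In this assay, going by the values given here, compound 4 is expected to give about 40%, with a likely range from 20% to 60%, the range being wide since the one earlier step is within the scatter and the place of the change is not the same.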

Compound 4, a percentage reported as activity, at one dose (the size of the read-out at that dose, not a potency): 20%
Compound 4: the middle estimate sits 20 percentage points above what was measured, and the stated range covers the measured number.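

Nitro in place of methyl on an aromatic carbon, here meta to a group of 7 heavy atoms, gives in this assay a number 30 percentage points lower from compound 2 to compound 4 (beyond the scatter). Set beside the earlier step, the size of this change does not carry over from one core to the other: the same change on two cores in this assay, a number 10 percentage points lower (within the scatter) from compound 1 to compound 3 and a number 30 percentage points lower (beyond the scatter) from compound 2 to compound 4, 20 percentage points apart, beyond the scatter of two such steps This shows that a step read on one core of the series is a poor guide to the size of the same change on the other, but two steps give no rule, and they do not tell whether the gap follows from the place of the nitro or from something else in the difference between the cores, nor do they show that the change would lower the number on any further core.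

The compounds shown carry only methyl and nitro on the aromatic ring, so how an amine, a carboxylic acid or a longer chain in those places would read in this assay stays open. Also open, going by these compounds, is whether a gap of this kind between the two cores belongs to the nitro alone or would appear with such other groups as well.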